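Dichlorophenyl thiophene amides: piperidinyl amide in place of cyclopentyl amide

The source may hold more compounds than are shown below. What is called first, only, known or untested is meant among the compounds shown, and "the series" means these compounds.

Among the compounds with values here, compound 1 `Nc1sc(-c2ccc(Cl)cc2)c(-c2ccc(Cl)cc2)c1C(=O)NC1CCCC1` is the only member of this series with a number on record. In a functional assay on PC-3 cells (Homo sapiens) for inhibition, read by sulforhodamine B assay, with a stated time of 72 h (on this read-out lower numbers stand for stronger inhibition and higher numbers for weaker inhibition), compound 1 gives 21200 nM, a weak result, and it therefore stands alone at the top of what is shown. Compound 2 `CCN(CC)CCNC(=O)Nc1sc(-c2ccc(Cl)cc2)c(-c2ccc(Cl)cc2)c1C(=O)NC1CC1` belongs to the same set, and in this assay compound 2 gives "not determined" (no result reported). Compound 3 `CS(=O)(=O)Nc1sc(-c2ccc(Cl)cc2)c(-c2ccc(Cl)cc2)c1C(=O)NC1CC1` also belongs to it, and in this assay compound 3 gives "not determined" (no result reported). So no step between two measured compounds can be drawn.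

Compound 4 `Nc1sc(-c2ccc(Cl)cc2)c(-c2ccc(Cl)cc2)c1C(=O)N1CCCCC1` keeps the shared core of compound 1 with its two chlorophenyl groups and differs only at the carbonyl carbon, (piperidin-1-yl in place of cyclopentylamino on a carbonyl carbon). Within the data shown here, with no measured pair to lean on, the expected step from compound 1 is a 1.4-fold higher number from compound 1 to compound 4 (0.15 log units; within the scatter), that is, a change of modest size in either direction, quite possibly not beyond the usual scatter. On that basis compound 4 is expected to give about 30000 nM in this assay, with a plausible range from 8000 nM to 100000 nM, because compound 1 sits at 21200 nM and nothing in the series points clearly elsewhere.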

Compound 4, half-maximal inhibitory concentration: 14300 nM
Estimate against measurement, compound 4: 2.1-fold (0.32 log units) above, and the stated range covers the measured number.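

Replacing cyclopentylamino with piperidin-1-yl on a carbonyl carbon, with the same number of heavy atoms on each side, gives a 1.5-fold lower number from compound 1 to compound 4 (0.17 log units; within the scatter) in this assay. The amide hydrogen of compound 1 is absent from compound 4, and the read-out does not move beyond the usual scatter, so for this one pair neither the loss of that hydrogen nor the change of ring registers in the number. No measurement available here explains this result.

Steps to compound 2 and compound 3 cannot be read, so this pair remains the only comparison at this carbonyl carbon. Still open, as far as these compounds go, is whether morpholin-4-yl, an open chain such as hexylamino, or a ring bearing a carboxylic acid at this place would stay in the same range.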